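Chain-end swap from compound 2 to compound 3

The source may report more compounds than this note shows. Statements on the series, on what has been measured and on what is new or still open speak of the compounds shown alone.

compound 1 `COC(=O)CCCCCCCCCCCCCC/C=C1\CC(CO)(COC(=O)C(C)(C)C)OC1=O`: 7.8 ug/mL
compound 2 `CC(C)(C)C(=O)OCCCCCCCCCCCCCCC/C=C1\CC(CO)(COC(=O)C(C)(C)C)OC1=O`: 3.46 ug/mL
compound 3 `CC(=O)NCCCCCCCCCCCCCCC/C=C1\CC(CO)(COC(=O)C(C)(C)C)OC1=O`: not yet measured

In a functional assay on SK-MEL-5 cells (Homo sapiens) for antiproliferative activity (on this read-out higher numbers stand for weaker inhibition of growth and lower numbers for stronger inhibition of growth), compound 2 gives 3.46 ug/mL, the lower of the two numbers. The next change is acetamido in place of ((tert-butyl)carbonyl)oxy on a saturated chain carbon, ten or more bonds along the chain from a double-bonded chain carbon. Within the data shown here, only one measured step bears on it, at the same place on the chain: a 2.3-fold lower number from compound 1 to compound 2 (0.35 log units; beyond the scatter). That step is modest and involves a different pair of groups, so it offers only a rough guide to size and direction. A similarly modest rise in the number is expected, described as a 1.7-fold higher number from compound 2 to compound 3 (0.24 log units; within the scatter). For compound 3 the estimated value is 6 ug/mL, with an expected range of 2.5 ug/mL to 14 ug/mL.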

Compound 3, concentration for 50% growth inhibition: > 10 ug/mL
Compound 3: no number, only a limit; the forecaster's own chance of this, stated with the estimate: 3%; at least 1.6-fold (0.22 log units) between middle value and limit.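

In this assay compound 3 gives a limit and not a number: the limit of > 10 ug/mL in this assay, at which 1 of the 3 values shown sits.

Even so, the chain end proves able to carry the read-out up as well as down, with acetamido in place of ((tert-butyl)carbonyl)oxy giving an at least 2.8-fold higher number from compound 2 to compound 3 (0.46 log units; beyond the scatter). Against the methoxycarbonyl end the step is an at least 1.2-fold higher number from compound 1 to compound 3 (0.10 log units; that floor lies within the scatter), a floor that leaves the order of those two unsettled.

Still open, going by these compounds, is how far the true number for compound 3 lies past its limit. Also open, on these data alone, is whether a free amine, a carboxylic acid or a longer chain at this position would match the lower number of compound 2.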